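The source may report more compounds than this note shows. Statements on the series, on what has been measured and on what is new or still open speak of the compounds shown alone.

Measured compounds in a functional assay on DU-145 cells (Homo sapiens) for cytotoxicity, read by sulforhodamine B assay, with a stated time of 48 h; a lower number here means a stronger inhibitor, a higher number a weaker inhibitor:

compound 1, `CC(=O)OC[C@H]1O[C@@H](n2cc(Cn3cc(C(C)=O)c4ccccc43)nn2)[C@H](OC(C)=O)[C@@H](OC(C)=O)[C@@H]1OC(C)=O`, gives 75200 nM
compound 2, `CC(=O)OC[C@H]1O[C@@H](n2cc(Cn3cc(/C=C4/C(=O)Nc5ccc(F)cc54)c4ccccc43)nn2)[C@H](OC(C)=O)[C@@H](OC(C)=O)[C@@H]1OC(C)=O`, gives 87400 nM
compound 3, `COc1ccc(/C=C2\C(=O)N(Cc3cn([C@@H]4O[C@H](COC(C)=O)[C@@H](OC(C)=O)[C@H](OC(C)=O)[C@H]4OC(C)=O)nn3)c3ccccc32)cc1OC`, gives 24900 nM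

Compound 3 stands at the lowest number of the three; compound 1 with 75200 nM and compound 2 with 87400 nM both lie beyond the scatter above it. Compound 4, `CC(=O)OC[C@H]1O[C@@H](n2cc(CN3C(=O)/C(=C\c4ccco4)c4ccccc43)nn2)[C@H](OC(C)=O)[C@@H](OC(C)=O)[C@@H]1OC(C)=O`, has not yet been measured in this assay. It differs from compound 3 in one place: furan-2-yl in place of 3,4-dimethoxyphenyl on a double-bonded chain carbon bound to a double-bonded ring carbon.

For the measured compounds named here, only one measured step between neighbours exists, a 1.2-fold higher number from compound 1 to compound 2 (0.07 log units; within the scatter), and it concerns a different position of the shared core and a different kind of exchange, so it does not bear directly on the change from compound 3 to compound 4. Going by the values given here, no measured pair shows what replacing a 3,4-dimethoxyphenyl by a furan-2-yl does at this position. With nothing to anchor a direction, the expected step in this assay is a 1.4-fold higher number from compound 3 to compound 4 (0.15 log units; within the scatter), a small shift that may well stay within the scatter. Compound 4 is therefore estimated at 35000 nM, with a range from 12000 nM to 100000 nM.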

Compound 4, half-maximal inhibitory concentration: 16900 nM
For compound 4 the middle estimate is 2.1-fold (0.32 log units) above the measured one, within the range that was stated.
By their numbers in this assay, from the lowest: compounds 4 and 3 (each within the scatter of the next); then compounds 1 and 2 (each within the scatter of the next).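

In this assay, the step of a 1.5-fold lower number from compound 3 to compound 4 (0.17 log units; within the scatter) comes with furan-2-yl in place of 3,4-dimethoxyphenyl on a double-bonded chain carbon bound to a double-bonded ring carbon. For the compounds shown here, this is the only measured step at this place, and it shows that a five-membered aromatic ring and a six-membered aromatic ring of carbon only read alike here, with the rest of the molecule unchanged. No measurement at hand accounts for this result.

What the compounds shown leave open is how far this place accepts other groups, such as a thiophen-2-yl, a carboxylic acid or a longer alkyl chain. They also leave open whether a plain phenyl, without the two methoxy groups, would read like compound 3.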